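The source may report more compounds than this note shows. Statements on the series, on what has been measured and on what is new or still open speak of the compounds shown alone.

Measured in a functional assay on MV4-11 cells (Homo sapiens) for antiproliferative activity, read by CellTiter-Glo, with a stated time of 72 h; on this read-out lower numbers stand for stronger inhibition of growth and higher numbers for weaker inhibition of growth:
- Compound 1 `Fc1cc(-c2csc(NCC3CCOCC3)n2)c(Cl)cn1`: > 10000 nM, a limit of the assay and not a number
- Compound 2 `N[C@H]1CC[C@H](Nc2cc(-c3csc(NCC4CCOCC4)n3)c(Cl)cn2)CC1`: 140 nM
- Compound 3 `N[C@H]1CC[C@H](CNc2cc(-c3csc(NCC4CCOCC4)n3)c(Cl)cn2)CC1`: 1900 nM

Only two of these results are true numbers, and compound 2 holds the lower one. The gap between them is a 14-fold higher number from compound 2 to compound 3 (1.13 log units; beyond the scatter).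

Compound 4 `O=C(N[C@H]1CC[C@H](Nc2cc(-c3csc(NCC4CCOCC4)n3)c(Cl)cn2)CC1)C1CC1` keeps compound 2 intact except at one place: cyclopropylcarbonyl in place of hydrogen on an amine nitrogen. The same change reads as amino to (cyclopropylcarbonyl)amino.

Among the compounds with values here, no measured step alters that amine nitrogen directly, so the evidence is indirect. Installing the (4-aminocyclohexyl)amino group gave an at least 71-fold lower number from compound 1 to compound 2 (1.85 log units; beyond the scatter), which shows how much the number depends on this part of compound 2. Extending the link to it gave a 14-fold higher number from compound 2 to compound 3 (1.13 log units; beyond the scatter), so even a small alteration here was costly. On that basis, a higher number is expected in this assay, and the estimated size is a 5.7-fold higher number from compound 2 to compound 4 (0.76 log units; beyond the scatter). For compound 4 the estimate is 800 nM, with an expected range of 150 nM to 5000 nM.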

Compound 4, concentration for 50% growth inhibition: > 10000 nM
Compound 4: no number, only a limit (the forecaster's own chance of this, stated with the estimate: 7%); at least 12-fold (1.09 log units) between middle value and limit.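

Within the data shown here, until this result the amine nitrogen of compound 2 had not itself been changed, and capping it while leaving the rest of the molecule intact gives an at least 71-fold higher number from compound 2 to compound 4 (1.85 log units; beyond the scatter). So, in this assay, the effect of compound 2 depends on this nitrogen not carrying cyclopropylcarbonyl, a sharper finding than the earlier ones, which altered the link to this group or removed the whole group. Compound 4 gives > 10000 nM, a limit of the assay and not a number, so the true size of the step stays unknown, and compound 4 cannot be ranked against compound 1: the limit of > 10000 nM in this assay, at which 2 of the 4 values shown sit.

From the compounds shown here alone, it remains open whether the loss follows from the carbonyl or from the three-membered ring. An acetyl group on this nitrogen would keep the carbonyl without that ring, while a methyl group would keep an amine.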